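A few compounds are considered here, and "the series" means these few. Any claim that something is new, unique, unknown or untested is made for them only; others in the source may bear on it.

For the measured compounds named here, in a functional assay on HeLa cells (Homo sapiens) for inhibition, read by MTT assay, with a stated time of 72 h (a lower number here means a stronger inhibitor, a higher number a weaker inhibitor), compound 1 (`Cc1noc(C)c1-c1cnc(N)c(Oc2ccc(C(=O)Nc3ccccc3Cl)cc2)n1`) gives 81300 nM, the higher of the two numbers measured so far, which makes it the weaker inhibitor. Compound 2 (`Cc1noc(C)c1-c1cnc(N)c(Oc2ccc(C(=O)Nc3ccc(Cl)cn3)cc2)n1`) gives 19200 nM. The next compound, compound 3 (`Cc1noc(C)c1-c1cnc(N)c(Oc2ccc(C(=O)Nc3ncccc3Cl)cc2)n1`), differs from compound 1 only in the group on the amide-type nitrogen, where 3-chloropyridin-2-yl stands in place of 2-chlorophenyl: 3-chloropyridin-2-yl in place of 2-chlorophenyl on an amide-type nitrogen. Going by the values given here, only one measured step bears on this change, a 4.2-fold lower number from compound 1 to compound 2 (0.63 log units; beyond the scatter), which is modest but beyond the scatter. That step also brings in a chloropyridinyl group on the same nitrogen, but the group is 5-chloropyridin-2-yl rather than 3-chloropyridin-2-yl, so it serves only as a partial guide. Among the compounds with values here, no measurement yet shows how much the difference between these two groups matters. A shift in the same direction as a 4.2-fold lower number from compound 1 to compound 2 (0.63 log units; beyond the scatter) is therefore expected, though probably a smaller one, and it may not clear the scatter. The expected change is a 2.1-fold lower number from compound 1 to compound 3 (0.33 log units; beyond the scatter). For compound 3 the estimated value is 38000 nM, with an expected range from 14000 nM to 95000 nM.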

Compound 3, half-maximal inhibitory concentration: 31900 nM
For compound 3 the middle estimate is 1.2-fold (0.08 log units) above the measured one; the measured number falls inside the stated range.
By their numbers in this assay, from the lowest: compounds 2 and 3 (each within the scatter of the next); then compound 1.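

In this assay, placing 3-chloropyridin-2-yl on the amide-type nitrogen in place of 2-chlorophenyl gives a 2.5-fold lower number from compound 1 to compound 3 (0.41 log units; beyond the scatter) and so shows that a second chloropyridinyl group also lowers the number, a modest change beyond the scatter that the earlier pair could only suggest. The two chloropyridinyl groups themselves cannot be told apart at this position, since the change between them is a 1.7-fold higher number from compound 2 to compound 3 (0.22 log units; within the scatter) and thus stays within the scatter, so among these three compounds the gain goes with having either chloropyridinyl group rather than 2-chlorophenyl. Nothing at hand accounts for this shift, although the count does show that each pyridinyl group brings one hydrogen-bond acceptor where 2-chlorophenyl has none.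

The compounds shown leave open whether the chlorine matters at all, as a plain pyridin-2-yl group or one carrying a methoxy group or a nitrile in its place would test. They also leave open whether a group without an aromatic ring on this nitrogen, such as a cyclohexyl group or a longer alkyl chain, would keep or lose the change seen here.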